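Fluorinated benzyl variants on a nucleoside core

A few compounds are considered here, and "the series" means these few. Any claim that something is new, unique, unknown or untested is made for them only; others in the source may bear on it.

Measured so far:
compound 1 `OC[C@H]1O[C@@H](n2cnc3c(NCc4cccc(F)c4)ncnc32)[C@H](O)[C@@H]1O` — > 166000 nM
compound 2 `COc1cc(CNc2ncnc3c2ncn3[C@@H]2O[C@H](CO)[C@@H](O)[C@H]2O)cc(OC)c1` — "not determined" (no result reported)

In a functional assay on G-361 cells (Homo sapiens) for antiproliferative activity, with a stated time of 72 h (on this read-out lower numbers stand for stronger inhibition and higher numbers for weaker inhibition), compound 1 gives only a limit, > 166000 nM, with no single number. Compound 2 has no result in this assay. Among the measured compounds shown here, compound 1 thus stands at the limit of > 166000 nM in this assay, at which 1 of the 2 values shown sits, and no measured step is known.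

Compound 3 `OC[C@H]1O[C@@H](n2cnc3c(NCc4ccc(F)c(F)c4F)ncnc32)[C@H](O)[C@@H]1O` differs from compound 1 by 2,3,4-trifluorophenyl in place of 3-fluorophenyl on a saturated chain carbon bound to a nitrogen on an aromatic ring. For the measured compounds named here, with no step measured, no change beyond the scatter is expected from compound 1 to compound 3 in this assay; the step expected is a step that the limit leaves unreadable from compound 1 to compound 3. Compound 3 is therefore expected to give about 200000 nM, between 80000 nM and 500000 nM, most likely again reported only as a limit.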

Compound 3, half-maximal inhibitory concentration: > 166000 nM
Compound 3 gave a limit, no number; the forecaster's own chance of this, stated with the estimate: 80%; the middle value is on the limit's open side.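

Compound 1 and compound 3 both give only a limit, not a number, in this assay, so no step can be read between them: the limit of > 166000 nM in this assay, at which 2 of the 3 values shown sit. On these data alone, whether any phenyl variant on the shared core gives a single number in this assay stays open.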